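The source may hold more compounds than are shown below. What is called first, only, known or untested is meant among the compounds shown, and "the series" means these compounds.

Measured so far:
- Compound 1 `CCCOC(=O)/C=C/c1ccc(NC(=O)C2(NC(=O)c3ccc4c(C5CCCC5)c(-c5ncc(Cl)cn5)n(C)c4c3)CCC2)cc1OCC`: > 5 h
- Compound 2 `CCOc1cc(NC(=O)C2(NC(=O)c3ccc4c(C5CCCC5)c(-c5ncc(Cl)cn5)n(C)c4c3)CCC2)ccc1/C=C/C(=O)OCC(Cl)(Cl)Cl`: > 5 h

In an ADME assay on a cell-free system (plasma, Homo sapiens) for pharmacokinetics (a lower number here means that the compound disappears faster, a higher number that the compound lasts longer), compound 1 gives > 5 h, which is a limit and not a number. Compound 2 gives > 5 h, which is also a limit. Compound 1 therefore has no exact place on the scale, and the two values together amount to the limit of > 5 h in this assay, at which 2 of the 2 values shown sit.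

Compound 3 `CCOc1cc(NC(=O)C2(NC(=O)c3ccc4c(C5CCCC5)c(-c5ncc(Cl)cn5)n(C)c4c3)CCC2)ccc1/C=C/C(=O)OCC(=O)N1CCOCC1` differs from compound 1 in one place: (morpholin-4-yl)carbonyl in place of ethyl on a saturated chain carbon bound to an oxygen next to a carbonyl group. In words, (morpholin-4-yl)carbonyl stands in place of ethyl on a saturated chain carbon bound to an oxygen next to a carbonyl group.

Among the measured compounds shown here, one measured step bears on this change, as it falls at the same place: a step that the two limits leave unreadable from compound 1 to compound 2. Its size cannot be read, so it offers no measure for the new change, and any expectation here remains loose.

A shorter half-life than that of compound 1 is nevertheless expected, with the estimated step being an at least 2.5-fold lower number from compound 1 to compound 3 (0.39 log units; beyond the scatter). In this assay, the expected half-life of compound 3 is 2 h, with an estimated range of 0.2 h to 8 h.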

Compound 3, half-life: > 5 h
Compound 3: a limit, no number (the forecaster's own chance of this, stated with the estimate: 35%); middle value at least 2.5-fold (0.39 log units) away from the limit.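

In this assay compound 3 gives > 5 h, which is a limit and not a number. The steps from compound 1 and compound 2 to compound 3 cannot be read, because all three compounds sit at the same limit: the limit of > 5 h in this assay, at which 3 of the 3 values shown sit.

The compounds shown leave open how long each one actually lasts, and whether the three esters differ in half-life at all.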